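Working notes: aryl exchange on a cinnamate-type ester series

This account rests on a few compounds, and the source may have more. Where it says the series, first, only, none or still open, it means among the compounds named here.

Three esters have been measured so far. Compound 1 `COc1ccccc1/C=C/C(=O)OC/C=C/c1cc(OC)c(OC)cc1OC` gives 100% in a functional assay on the whole organism (strain Kunming) with Mus musculus as the target, with a stated time of 0.5 h, at a dose of 300 mg/kg by the intraperitoneal route; a higher number here means a weaker effect of the compound at the dose given, a lower number a stronger effect. Compound 2 `COc1cc(OC)c(OC)cc1/C=C/COC(=O)/C=C/c1ccc(OC)c(OC)c1` gives 100% in this assay, and compound 3 `COc1cc(OC)c(OC)cc1/C=C/COC(=O)/C=C/c1cc(OC)c(OC)c(OC)c1OC` gives 100%. Compound 2 thus stands level with compounds 1 and 3 at the digits shown. Within the data shown here, the single one-place step measured, no change at the digits printed from compound 1 to compound 2 (within the scatter), lies within the scatter.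

Compound 4 `COc1cc(OC)c(OC)cc1/C=C/COC(=O)/C=C/c1ccc(Br)cc1` is not yet measured. It differs from compound 2 by 4-bromophenyl in place of 3,4-dimethoxyphenyl on a double-bonded chain carbon bound to a double-bonded chain carbon. Among the measured compounds shown here, only the step from compound 1 to compound 2 bears on an aryl exchange at this position, and it was flat. For the measured compounds named here, the entering group, however, carries no hydrogen-bond acceptors, for which no step exists, so some loss cannot be excluded. Compound 4 is therefore expected at 95%, with a range from 60% to 100%. The expected step is a number 5 percentage points lower from compound 2 to compound 4 (within the scatter).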

Compound 4, a percentage reported as activity, at one dose (the size of the read-out at that dose, not a potency): 100%
Compound 4: middle estimate off by 5 percentage points, on the low side, within the range that was stated.
By their numbers in this assay, from the lowest: compounds 1, 2, 3 and 4 (each within the scatter of the next).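

The aryl exchange on a double-bonded chain carbon bound to a double-bonded chain carbon now extends to a group without methoxy substituents. In this assay the exchange for 4-bromophenyl gives (no change at the digits printed from compound 2 to compound 4 (within the scatter)) and (no change at the digits printed from compound 1 to compound 4 (within the scatter)). A ring with 0 hydrogen-bond acceptors therefore reads level with rings carrying methoxy groups, so these acceptors are not needed to hold the read-out at this level.

From the compounds shown here alone, whether any group at this place moves the read-out remains open, for instance an aminomethyl group or a carboxylic acid on the phenyl ring. No measured evidence bears on why the read-out stays level.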